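Two Fluorines on the Benzyl Group: An Expected Step

The source may report more compounds than this note shows. Statements on the series, on what has been measured and on what is new or still open speak of the compounds shown alone.

Measured in a functional assay on HepG2 cells (Homo sapiens) for antiproliferative activity, read by MTT assay, with a stated time of 24 h; a higher number here means a weaker inhibitor, a lower number a stronger inhibitor:
compound 1, `c1ccc(CSc2nnc(-c3ccc4c(c3)OCCO4)n2-c2ccccc2)cc1`, gives 5960 nM
compound 2, `Clc1cccc(CSc2nnc(-c3ccc4c(c3)OCCO4)n2-c2ccccc2)c1`, gives 2390 nM

Both compounds share one core and differ only in the ring carried on the saturated chain carbon bound to a sulfur. Compound 1 carries a plain phenyl there and has the highest number of the two, so it is the weaker inhibitor of the pair. Among the compounds with values here, its only neighbour is compound 2, reached by a 2.5-fold lower number from compound 1 to compound 2 (0.40 log units; beyond the scatter); that single halogen on the ring brought a clear but modest gain.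

Compound 3, `Fc1cccc(F)c1CSc1nnc(-c2ccc3c(c2)OCCO3)n1-c1ccccc1`, is not yet measured. Its change from compound 1 is 2,6-difluorophenyl in place of phenyl on a saturated chain carbon bound to a sulfur. Within the data shown here, the one measured step that bears on this is the step from compound 1 to compound 2, where one halogen on the same ring gave a modest drop in the number. Two halogens on that ring are therefore expected to give a step of similar size in the same direction, namely a 2.0-fold lower number from compound 1 to compound 3 (0.30 log units; within the scatter). The number for compound 3 is estimated at 3000 nM, with a likely range from 1200 nM to 8000 nM.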

Compound 3, half-maximal inhibitory concentration: 2070 nM
Compound 3: middle estimate off by 1.4-fold (0.16 log units), on the high side; measured number inside the range.
By their numbers in this assay, from the lowest: compounds 3 and 2 (each within the scatter of the next); then compound 1.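

In this assay, the change to 2,6-difluorophenyl gives a 2.9-fold lower number from compound 1 to compound 3 (0.46 log units; beyond the scatter), so a second halogen-bearing ring, this time with fluorine rather than chlorine, also gives a lower number than the plain phenyl of compound 1. The two halogen-bearing rings cannot be told apart, however: the change from 3-chlorophenyl to 2,6-difluorophenyl gives a 1.2-fold lower number from compound 2 to compound 3 (0.06 log units; within the scatter), so in this assay the ring with two fluorines shows no gain over the ring with one chlorine, and a higher halogen count brings no visible extra effect. Nothing at hand says what lies behind these shifts.

The compounds shown cannot separate the kind of halogen from the number of halogens, since compound 2 and compound 3 differ in both at once. Also open, on these data alone, is whether a halogen is needed at all, and how a ring carrying a methoxy group, an amine or a carboxylic acid would compare, or a longer chain joining the ring to the sulfur.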